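From 4-chlorobenzyl to 2,6-difluorobenzyl on the shared core

This account rests on a few compounds, and the source may have more. Where it says the series, first, only, none or still open, it means among the compounds named here.

Of the compounds shown here, three sharing one core have been measured in a functional assay on HCT-116 cells (Homo sapiens) for inhibition, read by MTT assay, with a stated time of 48 h; on this read-out lower numbers stand for stronger inhibition and higher numbers for weaker inhibition. Compound 1 (`Fc1ccccc1CSc1nnc(-c2ccncc2)n1-c1ccccc1`) gives 12000 nM, compound 2 (`Fc1ccc(CSc2nnc(-c3ccncc3)n2-c2ccccc2)cc1`) gives 12800 nM and compound 3 (`Clc1ccc(CSc2nnc(-c3ccncc3)n2-c2ccccc2)cc1`) gives 10700 nM. Compound 3 therefore stands level with the other two, and its number cannot be separated from theirs.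

The unmeasured compound 4 (`Fc1cccc(F)c1CSc1nnc(-c2ccncc2)n1-c1ccccc1`) has 2,6-difluorophenyl in place of 4-chlorophenyl on a saturated chain carbon bound to a sulfur.

All three measured steps bear on this change, since each alters only the group at that same carbon. They are a 1.1-fold higher number from compound 1 to compound 2 (0.03 log units; within the scatter), a 1.1-fold lower number from compound 1 to compound 3 (0.05 log units; within the scatter) and a 1.2-fold lower number from compound 2 to compound 3 (0.08 log units; within the scatter). Each stays within the scatter, so this position has shown no sensitivity so far. However, 2,6-difluorophenyl itself has not been tested, and three close analogues offer only a narrow basis for the expectation.

Within the data shown here, with those steps as the only guide, no change beyond the scatter is expected in this assay, and no direction can be relied on. The expected step is a 1.1-fold higher number from compound 3 to compound 4 (0.03 log units; within the scatter). For compound 4 the estimate is 11500 nM, with an expected range of 6500 nM to 20000 nM.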

Compound 4, half-maximal inhibitory concentration: 22100 nM
Beside the measured number, compound 4's estimate is 1.9-fold (0.28 log units) below it, and the stated range ends below it.
By their numbers in this assay, from the lowest: compounds 3, 1, 2 and 4 (each within the scatter of the next, the first and the last beyond it).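

Among these compounds, this position no longer looks entirely flat in this assay: the change gives a 2.1-fold higher number from compound 3 to compound 4 (0.32 log units; beyond the scatter), the only step at this carbon that passes the scatter, and only modestly. The other two steps to the 2,6-difluorophenyl group stay within the scatter, at a 1.7-fold higher number from compound 2 to compound 4 (0.24 log units; within the scatter) and a 1.8-fold higher number from compound 1 to compound 4 (0.27 log units; within the scatter), so the separation holds against 4-chlorophenyl alone, and compound 4 cannot be told apart from compound 1 or compound 2. Among the compounds shown here, no supporting information is available that would account for the one step beyond the scatter.

Going by these compounds, all four groups at this carbon are halogen-bearing benzyl groups, so it remains open whether an unsubstituted benzyl, a methoxybenzyl or a carboxylic acid on a short chain would stay in this same narrow band or move clearly away from it. Also open, on these data alone, is whether the small difference between 4-chlorophenyl and 2,6-difluorophenyl would persist if the shared core were changed elsewhere, for example by an amine on the ring now carrying no substituent.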